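A few compounds are considered here, and "the series" means these few. Any claim that something is new, unique, unknown or untested is made for them only; others in the source may bear on it.

Compound 1 `CCCCCCCCCCCCCCCC(=O)NCCC(=O)Nc1cccc(S(=O)(=O)Nc2cccc(C)c2C)c1` is, in an in vitro assay on Sf9 cells for inhibition of CAAX prenyl protease 2 (Homo sapiens), tested at 10 uM (a higher number here means more inhibition at the concentration tested (going by the name of the read-out), a lower number less inhibition), the only one of the three measured compounds that gives a number, 18%. Compound 2 `CCCCCCCCCCCCCCCC(=O)NCCC(=O)Nc1cccc(S(=O)(=O)Nc2cccc3ccccc23)c1` gives in this assay a limit, < 5%. Compound 3 `CCCCCCCCCCCCCCCCCC(=O)NCCC(=O)Nc1cccc(S(=O)(=O)Nc2cccc(C)c2C)c1` likewise gives a limit, < 5%. Thus a number at least 13 percentage points lower from compound 1 to compound 2 (beyond the scatter) and a number at least 13 percentage points lower from compound 1 to compound 3 (beyond the scatter), both steps ending at the limit of < 5% in this assay, at which 2 of the 3 values shown sit. Compound 4 `CCCCCCCCCCCCCCCC(=O)N(C)CCC(=O)Nc1cccc(S(=O)(=O)Nc2cccc(C)c2C)c1` differs from compound 1 by methyl in place of hydrogen on an amide-type nitrogen. Among the compounds with values here, neither measured step touches that nitrogen, so neither bears directly on this change; both show only that changes elsewhere brought the number down to the limit. The expected step is therefore a number 6 percentage points lower from compound 1 to compound 4 (within the scatter), within the scatter. Compound 4 is estimated at 12%, between 5% and 25%.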

Compound 4, a percentage reported as inhibition, at one concentration (the size of the read-out at that concentration, not a potency): 22%
Compound 4: middle estimate off by 10 percentage points, on the low side; low and high end bracket the measured number.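

In this assay, methyl in place of hydrogen on the amide-type nitrogen gives a number 4 percentage points higher from compound 1 to compound 4 (within the scatter), so at this position the amide hydrogen can be replaced without a step beyond the scatter. Of the changes shown, this is the only one that does not end at a limit: the limit of < 5% in this assay, at which 2 of the 4 values shown sit.

The compounds shown leave open whether a larger group on this nitrogen, such as benzyl, or a chain ending in an amine or a carboxylic acid, would keep the number. They also leave open whether methyl here would give the same result with naphthalen-1-yl on the sulfonamide nitrogen.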